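Methoxy for trifluoromethyl on the benzyl of compound 3

The source may report more compounds than this note shows. Statements on the series, on what has been measured and on what is new or still open speak of the compounds shown alone.

Compound 3 `COc1ccc(-c2nn(-c3ccccc3)cc2C(=O)NCc2cn(Cc3ccc(C(F)(F)F)cc3)nn2)cc1` carries a trifluoromethyl on its benzyl ring. In a functional assay on MCF7 cells (Homo sapiens) for antiproliferative activity, read by sulforhodamine B assay, with a stated time of 48 h (a higher number here means a weaker inhibitor of growth, a lower number a stronger inhibitor of growth), compound 3 reaches only the assay limit, > 100000 nM. Compound 2 `COc1ccc(-c2nn(-c3ccccc3)cc2C(=O)NCc2cn(Cc3ccc(F)cc3)nn2)cc1`, with fluoro in that position, gives 460 nM in this assay. Within the data shown here, the one measured step that bears on the site, an at least 210-fold higher number from compound 2 to compound 3 (2.33 log units; beyond the scatter), shows that changing this substituent can move the read-out across the whole measured range; the two limit values, (the limit of > 100000 nM in this assay, at which 2 of the 3 values shown sit), mark where compound 3 sits. Compound 1 `COc1ccc(Cn2cc(CNC(=O)c3cn(-c4ccccc4)nc3-c3ccccc3)nn2)cc1` already carries a methoxybenzyl but lacks the methoxy on the other aryl ring, and in this assay compound 1 also gives only a limit, > 100000 nM.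

Compound 4 `COc1ccc(Cn2cc(CNC(=O)c3cn(-c4ccccc4)nc3-c3ccc(OC)cc3)nn2)cc1` differs from compound 3 by methoxy in place of trifluoromethyl on an aromatic carbon. Among the measured compounds shown here, no measured step gives methoxy against fluoro or trifluoromethyl at this place. Compound 2 with fluoro gives 460 nM in this assay. Compound 1 with methoxybenzyl reaches only a limit in this assay. Compound 4 is expected to fall between these, with a step of an at least 6.6-fold lower number from compound 3 to compound 4 (0.82 log units; beyond the scatter) estimated. Compound 4 is estimated at 15000 nM, within 800 nM to 100000 nM.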

Compound 4, concentration for 50% growth inhibition: 22900 nM
Beside the measured number, compound 4's estimate is 1.5-fold (0.18 log units) below it, within the range that was stated.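

Methoxy on the benzyl ring gives an at least 4.3-fold lower number from compound 3 to compound 4 (0.64 log units; beyond the scatter), so in this assay this site now reads a third group, and a measured number replaces a limit. Fluoro still stands apart from methoxy here, with a 50-fold higher number from compound 2 to compound 4 (1.70 log units; beyond the scatter), so the site does not merely separate fluoro from trifluoromethyl. The methoxy on the other aryl ring also counts with 4-methoxybenzyl held fixed, at an at least 4.3-fold lower number from compound 1 to compound 4 (0.64 log units; beyond the scatter), though compound 1 and compound 3 are both limits, so these two steps give only a minimum size: the limit of > 100000 nM in this assay, at which 2 of the 4 values shown sit.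

The compounds shown leave open how chloro, an amine or a carboxylic acid on the benzyl ring would read. Also open, going by these compounds, is whether the aryl methoxy counts to the same degree when the benzyl ring carries fluoro.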